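The source may report more compounds than this note shows. Statements on the series, on what has been measured and on what is new or still open speak of the compounds shown alone.

Measured so far:
compound 1, `COc1cc(-c2nnc(SCC(=O)c3ccccc3)n2N)cc(OC)c1OC`, > 100000 nM
compound 2, `COc1cc(-c2nnc(SCC(=O)c3ccc(C(F)(F)F)cc3)n2N)cc(OC)c1OC`, 3380 nM

Both numbers come from a functional assay on HeLa cells (Homo sapiens) for antiproliferative activity, read by MTT assay, with a stated time of 48 h; on this read-out lower numbers stand for stronger inhibition and higher numbers for weaker inhibition. Compound 1 sits at the limit of > 100000 nM in this assay, at which 1 of the 2 values shown sits, so for compound 1 only a limit is known, not a number. Compound 2 gives 3380 nM in this assay. For the measured compounds named here, the single measured step, an at least 29-fold lower number from compound 1 to compound 2 (1.47 log units; beyond the scatter), is the only guide available, and even its size is only a lower bound, since compound 1 stands at the limit.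

Compound 3, `COc1cc(-c2nnc(SCC(=O)c3ccccc3F)n2N)cc(OC)c1OC`, has not yet been measured in this assay. It differs from compound 1 in one place: fluoro in place of hydrogen on an aromatic carbon. Going by the values given here, no measured step shows fluoro entering anywhere, and the one step that is known, an at least 29-fold lower number from compound 1 to compound 2 (1.47 log units; beyond the scatter), concerns a different group at a different place, so it cannot be carried over directly. From the compounds shown here alone, a smaller change may shift the number less, and the direction remains open. The expected step is an at least 1.4-fold lower number from compound 1 to compound 3 (0.15 log units; that floor lies within the scatter), staying close to the limit. Compound 3 is therefore estimated at about 70000 nM in this assay, with a range from 15000 nM to 300000 nM.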

Compound 3, half-maximal inhibitory concentration: 80100 nM
Beside the measured number, compound 3's estimate is 1.1-fold (0.06 log units) below it, within the range that was stated.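

With fluoro on an aromatic carbon ortho to a large group, compound 3 gives a real number in this assay, yet the step reads only as an at least 1.2-fold lower number from compound 1 to compound 3 (0.09 log units; that floor lies within the scatter), so this change cannot be told apart from the usual spread of repeated measurements. That figure is a floor and not a true size because compound 1 sits at a limit and not at a number: the limit of > 100000 nM in this assay, at which 1 of the 3 values shown sits. The other comparison is much clearer, at a 24-fold higher number from compound 2 to compound 3 (1.37 log units; beyond the scatter), so 2-fluorophenyl on the carbonyl carbon falls well short of 4-(trifluoromethyl)phenyl, although this step changes both the group and its place on the ring at once.

The compounds shown leave open whether the group or its place accounts for that gap, since fluoro and trifluoromethyl never appear at the same place on the ring. They also leave open how a chloro group, a nitrile or an amine would read in the place of the fluoro in compound 3.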